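The source may hold more compounds than are shown below. What is called first, only, known or untested is meant among the compounds shown, and "the series" means these compounds.

Compound 1 `N#Cc1ccc(Cn2cncc2CNc2ccc(C(=O)NCc3ccccc3)c(-c3ccccc3)c2)cc1` is one of two compounds examined in a functional assay on NIH3T3 cells (Mus musculus); on this read-out lower numbers stand for an effect already at smaller amounts and higher numbers for an effect only at larger amounts of compound. In this assay compound 1 gives > 10 uM, which is a limit of the measurement rather than a number. Compound 2 `COC(=O)[C@H](CCSC)NC(=O)c1ccc(NCc2cncn2Cc2cccc([N+](=O)[O-])c2)cc1-c1ccccc1` belongs to the same set. In this assay compound 2 gives > 10 uM, likewise a limit. Both readings fall under (the limit of > 10 uM in this assay, at which 2 of the 2 values shown sit). Compound 3 `N#CCNC(=O)c1ccc(NCc2cncn2Cc2ccc(C#N)cc2)cc1-c1ccccc1` is not yet measured; it differs from compound 1 by cyano in place of phenyl on a saturated chain carbon bound to an amide-type nitrogen. Compound 1 stands only at a limit in this assay. The step that the limit leaves unreadable from compound 1 to compound 3 is expected to be none beyond the scatter. For compound 3 the estimate in this assay is 15 uM, with a range from 4 uM to 60 uM.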

Compound 3, concentration for half-maximal effect: > 10 uM
Compound 3: only a limit was reported; the forecaster's own chance of this, stated with the estimate: 70%; the middle value does not contradict the limit.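

No step can be read from compound 1 to compound 3, as both stand only at a limit in this assay: the limit of > 10 uM in this assay, at which 3 of the 3 values shown sit.

The compounds shown leave open at what concentration any of them reaches a half-maximal effect, and whether cyano in place of phenyl changes it.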